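The source may report more compounds than this note shows. Statements on the series, on what has been measured and on what is new or still open speak of the compounds shown alone.

Measured so far: compound 1 `Cc1nc(-c2ccccc2NCC2=NCCN2)co1` and compound 2 `Cc1ccsc1-c1ccccc1NCC1=NCCN1`.

In a functional assay for activation of Alpha-1B adrenergic receptor (Homo sapiens), read by calcium flux (on this read-out lower numbers stand for an effect already at smaller amounts and higher numbers for an effect only at larger amounts of compound), compound 1 gives only a limit, < 5020 nM. In this assay, going by the values given here, compound 2 gives 112 nM, the sole number among the two values shown. The step that the limit leaves unreadable from compound 1 to compound 2 has no readable size since it rests on the limit (the limit of < 5020 nM in this assay, at which 1 of the 2 values shown sits). Compound 3 `c1ccc(-c2cnccn2)c(NCC2=NCCN2)c1` differs from compound 2 by pyrazin-2-yl in place of 3-methylthiophen-2-yl on an aromatic carbon. Among the compounds with values here, no measured step bears on this change, so neither its direction nor its size can be read from the data. Compound 3 is expected to give 500 nM, spanning 100 nM to 3000 nM. The estimated change is a 4.5-fold higher number from compound 2 to compound 3 (0.65 log units; beyond the scatter).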

Compound 3, half-maximal effective concentration: 339 nM
The estimate for compound 3 lay 1.5-fold (0.17 log units) above the measured number, within the range that was stated.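

In this assay, going by these compounds alone, pyrazin-2-yl in place of 3-methylthiophen-2-yl on this aromatic carbon gives a 3.0-fold higher number from compound 2 to compound 3 (0.48 log units; beyond the scatter), the first readable step at this position. Both a five-membered and a six-membered aromatic ring here thus give a number rather than a limit. Compound 1 gives only a limit, so the steps from it cannot be read: the limit of < 5020 nM in this assay, at which 1 of the 3 values shown sits.

The two groups differ in ring size and in hetero atoms at once, and the compounds shown do not separate these. Going by these compounds, how a plain phenyl ring or a simple amine on this carbon would read remains open.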